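A few compounds are considered here, and "the series" means these few. Any claim that something is new, unique, unknown or untested is made for them only; others in the source may bear on it.

Compound 1 `CCc1cnc(OCC(C)(C)O)c(-c2ccc(S(C)(=O)=O)cc2)c1`: 1.4 h
Compound 2 `CCCOc1nc(OCC(C)(C)O)c(-c2ccc(S(C)(=O)=O)cc2)cc1CO`: 0.0517 h

Both compounds were tested in an ADME assay on cells (Hepatocyte, Homo sapiens) for metabolic stability; on this read-out higher numbers stand for a longer-lived compound and lower numbers for a shorter-lived compound. Compound 2 stands lowest of the two, and compound 1 lies above it by well beyond the usual scatter. The pair differ in more than one place, so that gap cannot be pinned on any single group.

Compound 3 `CCCCOc1nc(OCC(C)(C)O)c(-c2ccc(S(C)(=O)=O)cc2)cc1CO` has not yet been measured. It departs from compound 2 in one place only, methyl in place of hydrogen on a saturated chain carbon, three bonds along the chain from an oxygen on an aromatic ring, which turns propyl to butyl. Going by the values given here, no measured pair shows this change, so the closest guide is compound 2 at 0.0517 h. The expected step of a 1.0-fold lower number from compound 2 to compound 3 (0.01 log units; within the scatter) is estimated to stay within the scatter, with no clear direction. Compound 3 is therefore estimated at 0.05 h, with an expected range of 0.022 h to 0.11 h.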

Compound 3, half-life: 0.04 h
Compound 3: middle estimate off by 1.3-fold (0.10 log units), on the high side; the range from low to high includes it.
By their numbers in this assay, from the lowest: compounds 3 and 2 (each within the scatter of the next); then compound 1.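

In this assay, going by these compounds alone, the first direct reading of this position comes from the change of propyl to butyl, which gives a 1.3-fold lower number from compound 2 to compound 3 (0.11 log units; within the scatter) and so leaves the read-out within the scatter. For this pair, then, methyl in place of hydrogen on a saturated chain carbon, three bonds along the chain from an oxygen on an aromatic ring, has no clear effect, and the added carbon does not separate the two compounds. Nothing available explains why the read-out holds steady across this change.

The compounds shown leave open whether a longer chain such as pentyl, or a chain ending in an amine or a carboxylic acid, would behave the same way at this place. They also leave unassigned the gap to compound 1, which differs from compound 2 in more than one place.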